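The compounds below may be only part of what the source reports. "The series", "measured", "known", "first", "only" and "open" are said of these compounds alone.

Of the compounds shown here, three built on one shared core have been tested in an assay on isolated protein for binding affinity to Equilibrative nucleoside transporter 1 (Homo sapiens); on this read-out higher numbers stand for weaker inhibition and lower numbers for stronger inhibition. Compound 1 `Cc1c(CNc2ncnc3c2ncn3[C@@H]2O[C@H](CO)[C@@H](O)[C@H]2O)cccc1[N+](=O)[O-]` gives 427 nM. Compound 2 `Cc1ccc(CNc2ncnc3c2ncn3[C@@H]2O[C@H](CO)[C@@H](O)[C@H]2O)cc1[N+](=O)[O-]` gives 1170 nM. Compound 3 `O=[N+]([O-])c1cc(CNc2ncnc3c2ncn3[C@@H]2O[C@H](CO)[C@@H](O)[C@H]2O)ccc1Cl` gives 708 nM, the second highest of the three numbers, though the steps of a 1.7-fold higher number from compound 1 to compound 3 (0.22 log units; within the scatter) and a 1.7-fold lower number from compound 2 to compound 3 (0.22 log units; within the scatter) both stay within the scatter, so the three compounds sit close together. The next compound, compound 4 `COc1cccc(CNc2ncnc3c2ncn3[C@@H]2O[C@H](CO)[C@@H](O)[C@H]2O)c1`, has not yet been measured in this assay. The change is 3-methoxyphenyl in place of 4-chloro-3-nitrophenyl on a saturated chain carbon bound to a nitrogen on an aromatic ring. The two measured steps that reach compound 3 swap one substituted ring for another while keeping the nitro group, and neither crosses the scatter. For the measured compounds named here, no measured step removes the nitro group or brings in a methoxy group, so this change goes beyond what the measured steps cover. On that basis only a modest step is expected, a 2.1-fold higher number from compound 3 to compound 4 (0.33 log units; beyond the scatter), leaning toward a higher number. The estimate for compound 4 is 1500 nM, with a range from 400 nM to 6000 nM.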

Compound 4, half-maximal inhibitory concentration: 115000 nM
Compound 4: middle estimate off by 77-fold (1.88 log units), on the low side, and the stated range ends below it.
By their numbers in this assay, from the lowest: compounds 1, 3 and 2 (each within the scatter of the next, the first and the last beyond it); then compound 4.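

At this position, on a saturated chain carbon bound to a nitrogen on an aromatic ring, the three rings that carry a nitro group differ by modest steps at most, whereas 3-methoxyphenyl brings far larger ones in this assay: a 160-fold higher number from compound 3 to compound 4 (2.21 log units; beyond the scatter), a 98-fold higher number from compound 2 to compound 4 (1.99 log units; beyond the scatter) and a 270-fold higher number from compound 1 to compound 4 (2.43 log units; beyond the scatter). The position is therefore far more sensitive to the ring's substituents than the nitro-bearing compounds alone could show. Nothing available explains why the number climbs so steeply.

This change takes away the nitro group and the ring's other substituent and brings in a methoxy group all at once, so the effect of each remains unseparated. From the compounds shown here alone, it stays open how a plain phenyl ring would compare, or a ring carrying a nitrile or an amine in place of the nitro group.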